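This account rests on a few compounds, and the source may have more. Where it says the series, first, only, none or still open, it means among the compounds named here.

Measured so far in a functional assay on MCF7 cells (Homo sapiens) for cytotoxicity, read by MTT assay, with a stated time of 72 h; a lower number here means a stronger inhibitor of growth, a higher number a weaker inhibitor of growth:

compound 1, `C=CCOC(=O)Nc1ccc([Se]C#N)cc1`, compound 1 gives 15000 nM
compound 2, `CCCOC(=O)Nc1ccc([Se]C#N)cc1`, compound 2 gives 8000 nM
compound 3, `N#C[Se]c1ccc(NC(=O)Oc2ccccc2)cc1`, compound 3 gives 4000 nM

Compound 3 has the lowest of the three numbers. Its nearest neighbour is compound 2, with a 2.0-fold lower number from compound 2 to compound 3 (0.30 log units; within the scatter), a step that stays within the scatter, so no order between compound 2 and compound 3 can be claimed. Its furthest neighbour is compound 1, with a 3.8-fold lower number from compound 1 to compound 3 (0.57 log units; beyond the scatter), which is beyond the scatter but modest.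

Compound 4 is `CC(C)COC(=O)Nc1ccc([Se]C#N)cc1`. Relative to compound 3 the change is isobutyl in place of phenyl on an oxygen next to a carbonyl group. The two steps that bear on this are the reverse of those just named: the phenyl-for-alkyl exchanges from compound 2 and from compound 1 to compound 3. The step from the propyl carbamate, compound 2, is the closer model, since isobutyl, like propyl, is a saturated chain; it was within the scatter. The allyl step was larger but is less comparable. Going from phenyl back to a saturated chain is therefore expected to give at most a small rise in number, likely within the scatter, in this assay.

Compound 4 is expected to give 7000 nM in this assay, with a range of 3000 nM to 16000 nM. That estimate means an expected step of a 1.8-fold higher number from compound 3 to compound 4 (0.24 log units; within the scatter).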

Compound 4, concentration for 50% growth inhibition in the MCF7 assay: 18100 nM
Compound 4: middle estimate off by 2.6-fold (0.41 log units), on the low side, and the stated range ends below it.
By their numbers in the MCF7 assay, from the lowest: compounds 3, 2, 1 and 4 (each within the scatter of the next, the first and the last beyond it).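

Among these compounds, in the MCF7 assay the group on an oxygen next to a carbonyl group now shows a clearer effect, with isobutyl in place of phenyl giving a 4.5-fold higher number from compound 3 to compound 4 (0.66 log units; beyond the scatter) and the added methyl on the propyl chain giving a 2.3-fold higher number from compound 2 to compound 4 (0.35 log units; beyond the scatter); this is the first step between two saturated chains to pass the scatter. Isobutyl and allyl remain unresolved in the MCF7 assay, at a 1.2-fold higher number from compound 1 to compound 4 (0.08 log units; within the scatter). In a physicochemical assay, with a stated time of 180 min, tested at 0.5 mg/mL (on this read-out lower numbers stand for less inhibition and higher numbers for more inhibition at the one concentration tested (going by the name of the read-out)), compound 3 gives 19.3% and compound 4 gives 27.1%, with a number 7.8 percentage points higher from compound 3 to compound 4 (within the scatter), so only the MCF7 assay separates the pair, and no supporting data explain the gap.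

As far as these compounds go, whether a benzyl group on the same oxygen would stay with phenyl or fall with isobutyl remains open. So does the response to a longer chain, or to a chain ending in an amine.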